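Pyrimidine for pyridazine acid on the cyclopentene core

The source may hold more compounds than are shown below. What is called first, only, known or untested is meant among the compounds shown, and "the series" means these compounds.

Compound 2 `O=C(O)c1cc(C2=C(c3cc(Cl)ccc3OCc3ccccc3)CCC2)cnn1` was run in a physicochemical assay for lipophilicity (a higher number here means a more lipophilic compound, a lower number a more polar compound), and gives "not determined" (no result reported), so no number is available for it. The neighbours with numbers are compound 1 `O=C(O)c1cncc(C2=C(c3cc(C(F)(F)F)ccc3OCc3ccccc3)CCC2)c1`, which in this assay gives 2.7, and compound 3 `O=C(O)c1ccnc(C2=C(c3cc(Br)ccc3OCc3ccc(F)cc3)CCC2)c1`, which gives 2.7; these two values lie within the scatter of each other. Compound 4 `O=C(O)c1ccnc(C2=C(c3cc(Cl)ccc3OCc3ccccc3)CCC2)n1` is the next entry to be measured in this assay. The change from compound 2 to compound 4 is 4-carboxypyrimidin-2-yl in place of 6-carboxypyridazin-4-yl on a double-bonded ring carbon. Among the measured compounds shown here, with no step to anchor it, any shift is expected to stay within the scatter, without a clear direction. Compound 4 is expected to give 2.5 in this assay, within 1.9 to 3.1.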

Compound 4, distribution coefficient: 0.8
Estimate against measurement, compound 4: 1.70 log units above, outside the stated range (below it).
By their numbers in this assay, from the lowest: compound 4; then compounds 1 and 3 (each within the scatter of the next).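

Among the compounds shown here, no step to compound 4 can be read: compound 2 has no number, and compounds 1 and 3 differ from compound 4 in more than one place. The compounds shown leave open how 4-carboxypyrimidin-2-yl and 6-carboxypyridazin-4-yl compare in this assay on the shared core. No measurement shown bears on this result.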